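The compounds below may be only part of what the source reports. "The series", "measured", "known", "first", "only" and "open" are said of these compounds alone.

Measured so far:
Compound 1 `CCSC(=S)SCC(=O)c1ccccc1`: 5010 nM
Compound 2 `CCOC(=O)Nc1cccc(C(=O)CSC(=S)SCC)c1`: 2000 nM

In a functional assay on HeLa cells (Homo sapiens) for antiproliferative activity, read by resazurin assay (on this read-out higher numbers stand for weaker inhibition and lower numbers for stronger inhibition), compound 1 gives 5010 nM, the higher of the two numbers available, while compound 2 gives 2000 nM. Within the data shown here, compound 1 therefore marks the weaker end of this very small set, and the only measured step from it is a 2.5-fold lower number from compound 1 to compound 2 (0.40 log units; beyond the scatter). That step puts (ethoxycarbonyl)amino in place of hydrogen on an aromatic carbon.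

Compound 3 `CCSC(=S)SCC(=O)c1ccc(OC(F)F)cc1` keeps the core of compound 1 and differs by difluoromethoxy in place of hydrogen on an aromatic carbon. The new group, difluoromethoxy, also replaces hydrogen on an aromatic carbon, but it is a different substituent, so the measured step is only a loose guide. Among the measured compounds shown here, one step establishes no trend, and no measurement yet shows what difluoromethoxy does on this core. For the measured compounds named here, the reasonable expectation is a modest move towards a lower number, no larger than the step seen for compound 2, and it may not clear the scatter. The estimated change is a 1.7-fold lower number from compound 1 to compound 3 (0.22 log units; within the scatter). For compound 3 the expected value is 3000 nM, with an estimated range from 1100 nM to 7500 nM.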

Compound 3, half-maximal inhibitory concentration: 3980 nM
Beside the measured number, compound 3's estimate is 1.3-fold (0.12 log units) below it; measured number inside the range.
By their numbers in this assay, from the lowest: compounds 2, 3 and 1 (each within the scatter of the next, the first and the last beyond it).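

In this assay, difluoromethoxy on an aromatic carbon of the six-membered ring, para to a group of 9 heavy atoms, gives a 1.3-fold lower number from compound 1 to compound 3 (0.10 log units; within the scatter), so at this position the change does not separate the two compounds. Among these compounds, until now the only measured change on the ring had been a 2.5-fold lower number from compound 1 to compound 2 (0.40 log units; beyond the scatter), which lies beyond the scatter, and the new step shows that putting a group in place of hydrogen on an aromatic carbon of this core does not always produce a difference that can be read. No measurement given here accounts for the difference between the two steps, which involve different groups.

The compounds shown leave open whether another group at this position, such as an amine, a carboxylic acid or (ethoxycarbonyl)amino itself, would move the number beyond the scatter, and whether difluoromethoxy would behave the same elsewhere on the ring. They also leave open how much the ethyl group on sulfur contributes, since a longer chain or a benzyl group there does not appear among them.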